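The source may report more compounds than this note shows. Statements on the series, on what has been measured and on what is new or still open speak of the compounds shown alone.

Compound 1 `CC(C)=CCC1=CC(=O)c2ccccc2C1=O`: 15000 nM
Compound 2 `C=CC(O)C1=CC(=O)c2ccccc2C1=O`: 4300 nM

Within the data shown here, in a functional assay on WHCO1 cells (Homo sapiens) for cytotoxicity, read by MTT assay, with a stated time of 24 h (a lower number here means a stronger inhibitor, a higher number a weaker inhibitor), compound 2 gives the lowest of the two numbers, with compound 1 the nearest at a higher number; the one step between them, a 3.5-fold lower number from compound 1 to compound 2 (0.54 log units; beyond the scatter), is modest but real. Compound 3 `O=C1C=C(C(O)c2cccc(Cl)c2)C(=O)c2ccccc21` is still to be measured in this assay. It differs from compound 2 in one place: 3-chlorophenyl in place of vinyl on a saturated chain carbon bound to a double-bonded ring carbon and an oxygen on a saturated carbon. Among the measured compounds shown here, the only measured step concerns a different change, at the same part of the shared core, so no measured step bears directly on the new one; the hydroxyl on the saturated chain carbon, present in compound 2 and kept in compound 3, is retained. The expected step in this assay is therefore a 1.4-fold lower number from compound 2 to compound 3 (0.16 log units; within the scatter), within the usual scatter. Compound 3 is estimated at 3000 nM, with a range from 800 nM to 12000 nM.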

Compound 3, half-maximal inhibitory concentration: 7300 nM
Estimate against measurement, compound 3: 2.4-fold (0.39 log units) below; measured number inside the range.
By their numbers in this assay, from the lowest: compounds 2 and 3 (each within the scatter of the next); then compound 1.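

In this assay, putting 3-chlorophenyl in place of vinyl gives a 1.7-fold higher number from compound 2 to compound 3 (0.23 log units; within the scatter), so the two compounds cannot be told apart. The saturated chain carbon that carries the hydroxyl can therefore hold a much larger group, one with an aromatic ring, without the number moving beyond the scatter, something the earlier step, which changed the whole side chain, could not show. No measurement is available to explain why the number stays within the scatter.

Whether the chlorine matters remains open, since a plain phenyl is absent from the compounds shown. Also open, going by these compounds, is how this assay would read with an amine or a longer alkyl chain on this carbon, or with a ketone in place of the hydroxyl.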